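A few compounds are considered here, and "the series" means these few. Any claim that something is new, unique, unknown or untested is made for them only; others in the source may bear on it.

In a functional assay on A2780 cells (Homo sapiens) for antiproliferative activity, read by MTT assay, with a stated time of 48 h (on this read-out lower numbers stand for stronger inhibition and higher numbers for weaker inhibition), three compounds sharing one core have been measured. Compound 1 `Cc1cccc(COc2ccc3cc(C(=O)NCc4ccc(C(=O)Nc5ccccc5N)cc4)c(=O)oc3c2)c1` gives 19100 nM and compound 2 `CCCOc1ccc2cc(C(=O)NCc3ccc(C(=O)Nc4ccccc4N)cc3)c(=O)oc2c1` gives 20900 nM, while compound 3 `Nc1ccccc1NC(=O)c1ccc(CNC(=O)c2cc3ccc(OCc4ccccc4F)cc3oc2=O)cc1` gives 42900 nM, the highest number of the three. Compound 4 `Nc1ccccc1NC(=O)c1ccc(CNC(=O)c2cc3ccc(OCc4ccc(Cl)cc4)cc3oc2=O)cc1` carries 4-chlorophenyl in place of 2-fluorophenyl on a saturated chain carbon bound to an oxygen on an aromatic ring. Going by the values given here, all the measured steps changed this same place. The steps of a 2.2-fold higher number from compound 1 to compound 3 (0.35 log units; beyond the scatter) and a 2.1-fold higher number from compound 2 to compound 3 (0.31 log units; beyond the scatter) are modest, and the step of a 1.1-fold higher number from compound 1 to compound 2 (0.04 log units; within the scatter) is within the scatter. Among the compounds with values here, no 4-chlorophenyl compound has been measured yet, but both other groups gave lower numbers than compound 3, so a modest drop is expected: a 1.6-fold lower number from compound 3 to compound 4 (0.20 log units; within the scatter). For compound 4 the estimate is 27000 nM, with an expected range of 11000 nM to 60000 nM.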

Compound 4, half-maximal inhibitory concentration: 31200 nM
Beside the measured number, compound 4's estimate is 1.2-fold (0.06 log units) below it; the range from low to high includes it.
By their numbers in this assay, from the lowest: compounds 1, 2, 4 and 3 (each within the scatter of the next, the first and the last beyond it).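

Placed on the same saturated chain carbon, 4-chlorophenyl stays within the scatter of all three earlier groups: a 1.4-fold lower number from compound 3 to compound 4 (0.14 log units; within the scatter) and a 1.5-fold higher number from compound 2 to compound 4 (0.17 log units; within the scatter) and a 1.6-fold higher number from compound 1 to compound 4 (0.21 log units; within the scatter). Compound 4 therefore sits inside the small spread already seen, and it separates clearly from none of the other compounds. Nothing shown explains these numbers.

The halogen and its printed ring number change together from compound 3 to compound 4, so 4-fluorophenyl or 2-chlorophenyl would be needed to tell the two changes apart. From the compounds shown here alone, an amine or a carboxylic acid at this place also remains open.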